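Thiophene-fused series: amine substituent and nitric oxide inhibition

This account rests on a few compounds, and the source may have more. Where it says the series, first, only, none or still open, it means among the compounds named here.

Compounds measured so far in a functional assay on L02 cells (Homo sapiens) for inhibition, read by Griess assay, with stated times of 1 h and 24 h; on this read-out higher numbers stand for weaker inhibition and lower numbers for stronger inhibition:
compound 1 `COc1cc(/C=C/c2nc(Nc3ccc(C)cc3)c3sccc3n2)cc(OC)c1OC` – < 40000 nM
compound 2 `COc1cc(/C=C/c2nc(Nc3ccc(C(F)(F)F)cc3)c3sccc3n2)cc(OC)c1OC` – 436000 nM

The value of compound 1 in this assay is a limit, not a number (the limit of < 40000 nM in this assay, at which 1 of the 2 values shown sits). Compound 2 therefore stands as the only number shown in this assay. The measured step is an at least 10-fold higher number from compound 1 to compound 2 (1.03 log units; beyond the scatter), which came with trifluoromethyl in place of methyl on an aromatic carbon.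

Compound 3 `COc1cc(/C=C/c2nc(N(C)c3ccccc3)c3sccc3n2)cc(OC)c1OC` differs from compound 2 by methyl(phenyl)amino in place of (4-(trifluoromethyl)phenyl)amino on an aromatic carbon. For the measured compounds named here, the step from compound 1 to compound 2 bears on this change: it shows that removing the trifluoromethyl-bearing group may move the number back toward stronger inhibition, while the methyl on the amine nitrogen has no measured counterpart here. A step of moderate size toward stronger inhibition is therefore expected, a 4.4-fold lower number from compound 2 to compound 3 (0.64 log units; beyond the scatter), with wide uncertainty.

For compound 3 the estimate in this assay is 100000 nM, expected to lie between 20000 nM and 450000 nM.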

Compound 3, half-maximal inhibitory concentration: 767000 nM
Beside the measured number, compound 3's estimate is 7.7-fold (0.88 log units) below it; the measured number lies above the stated range.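

In this assay, methyl(phenyl)amino in place of (4-(trifluoromethyl)phenyl)amino gives a 1.8-fold higher number from compound 2 to compound 3 (0.25 log units; within the scatter), so these two groups cannot be told apart at this position. Methyl(phenyl)amino in place of (4-methylphenyl)amino gives an at least 19-fold higher number from compound 1 to compound 3 (1.28 log units; beyond the scatter), which leaves compound 1 alone, apart from the other two. The value of compound 1 is a limit, not a number: the limit of < 40000 nM in this assay, at which 1 of the 3 values shown sits.

The shown compounds do not separate the methyl on the amine nitrogen from the loss of the ring methyl within that step. Also open, from the compounds shown here alone, is how plain phenylamino or a morpholine would read in this assay.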